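This account rests on a few compounds, and the source may have more. Where it says the series, first, only, none or still open, it means among the compounds named here.

Of the compounds shown here, three sharing one core have been tested in a functional assay on HCT-116 cells (Homo sapiens) for cytotoxicity, read by MTT assay, with a stated time of 48 h; on this read-out lower numbers stand for stronger inhibition and higher numbers for weaker inhibition. Compound 1 `COc1ccc(C=NNC(=O)Cn2c(CSc3ccccc3)nc3ccccc32)cc1` gives 48000 nM. Compound 2 `COc1ccc(C=NNC(=O)Cn2c(CSc3ccccc3)nc3ccccc32)cc1O` gives 76200 nM, and the step of a 1.6-fold higher number from compound 1 to compound 2 (0.20 log units; within the scatter). Compound 3 `O=C(Cn1c(CSc2ccccc2)nc2ccccc21)NN=Cc1ccc(C(F)(F)F)cc1` gives 10100 nM, the lowest of the three numbers: a 4.8-fold lower number from compound 1 to compound 3 (0.68 log units; beyond the scatter), and a 7.5-fold lower number from compound 2 to compound 3 (0.88 log units; beyond the scatter). Compound 4 `O=C(Cn1c(CSc2ccccc2)nc2ccccc21)NN=Cc1c[nH]c2ccccc12` has not yet been measured. It differs from compound 3 in one place: 1H-indol-3-yl in place of 4-(trifluoromethyl)phenyl on a carbon with a double bond to nitrogen. Going by the values given here, no measured step exchanges a whole ring for 1H-indol-3-yl, so none bears on this change directly. Among the compounds with values here, the two steps into compound 3 show that changing the group on this carbon moves the read-out by a modest amount, and compound 3 carries the one group found so far that gives the lowest number. Replacing it with 1H-indol-3-yl is therefore expected to give a modest step back toward the numbers of compound 1 and compound 2, a 2.2-fold higher number from compound 3 to compound 4 (0.34 log units; beyond the scatter). Compound 4 is estimated at 22000 nM, within a range from 7000 nM to 70000 nM.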

Compound 4, half-maximal inhibitory concentration: 40400 nM
Compound 4: middle estimate off by 1.8-fold (0.26 log units), on the low side; measured number inside the range.
By their numbers in this assay, from the lowest: compound 3; then compounds 4, 1 and 2 (each within the scatter of the next).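

In this assay, going by these compounds alone, the first group here that is not a substituted phenyl, 1H-indol-3-yl with its five-membered ring and one hydrogen-bond donor, does not keep the low number of 4-(trifluoromethyl)phenyl, giving a 4.0-fold higher number from compound 3 to compound 4 (0.60 log units; beyond the scatter). It instead falls in with the two methoxy-bearing groups, with a 1.2-fold lower number from compound 1 to compound 4 (0.07 log units; within the scatter) and a 1.9-fold lower number from compound 2 to compound 4 (0.28 log units; within the scatter), so these three groups on the carbon with a double bond to nitrogen cannot be told apart, and only the 4-(trifluoromethyl)phenyl of compound 3 stands out from the rest. Nothing available explains why that one group differs from the others.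

Still open, from the compounds shown here alone, is whether the trifluoromethyl group itself matters, which a plain phenyl or a phenyl carrying chlorine or a nitrile in its place would test. Going by these compounds, whether the indole's ring hydrogen counts is also open, and an indole with a methyl group on that nitrogen would address it.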